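A few compounds are considered here, and "the series" means these few. Any claim that something is new, unique, unknown or untested is made for them only; others in the source may bear on it.

Compound 3 `Cc1ccc(C(=O)Nc2c(C(O)(C(F)(F)F)C(F)(F)F)ccc3ccccc23)cc1` gives 76 nM in an assay on LtK cells with ATP-sensitive inward rectifier potassium channel 11 (Homo sapiens) as the target (on this read-out higher numbers stand for an effect only at larger amounts of compound and lower numbers for an effect already at smaller amounts), and so stands highest of the two numbers here. Compound 2 `N#Cc1cccc(C(=O)Nc2c(C(O)(C(F)(F)F)C(F)(F)F)ccc3ccccc23)c1` gives 12 nM in this assay. Compound 1 `CCCC(C)C(=O)Nc1c(C(O)(C(F)(F)F)C(F)(F)F)ccc2ccccc12` reaches only a limit of the assay in this assay, > 10000 nM. Two steps show that replacing the 1-methylbutyl chain on the carbonyl carbon with an aromatic ring moves the number a long way down: an at least 830-fold lower number from compound 1 to compound 2 (2.92 log units; beyond the scatter) and an at least 130-fold lower number from compound 1 to compound 3 (2.11 log units; beyond the scatter). Between the two aromatic rings themselves the step is smaller, a 6.3-fold higher number from compound 2 to compound 3 (0.80 log units; beyond the scatter).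

Compound 4 `O=C(Nc1c(C(O)(C(F)(F)F)C(F)(F)F)ccc2ccccc12)c1cc(Cl)cc(Cl)c1` differs from compound 3 in one place: 3,5-dichlorophenyl in place of 4-methylphenyl on a carbonyl carbon. The aromatic ring on the carbonyl carbon is kept, so the large steps from compound 1 give no reason to expect a return toward the limit of compound 1. The swap of one substituted phenyl for another is of the kind seen in the step from compound 2 to compound 3, which was modest, so a step of similar size, in either direction, is expected: a 3.0-fold lower number from compound 3 to compound 4 (0.48 log units; beyond the scatter). For compound 4 the estimate is 25 nM, within a range from 8 nM to 80 nM.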

Compound 4, half-maximal effective concentration: 306 nM
Compound 4: middle estimate off by 12-fold (1.09 log units), on the low side; the whole stated range lies below it.
By their numbers in this assay, from the lowest: compound 2; then compound 3; then compound 4. At a limit, above all of these: compound 1.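

On this carbonyl carbon, an aromatic ring alone does not settle the result, since what the ring carries also counts: 3,5-dichlorophenyl gives a 4.0-fold higher number from compound 3 to compound 4 (0.60 log units; beyond the scatter) and a 26-fold higher number from compound 2 to compound 4 (1.41 log units; beyond the scatter). Compared with the 1-methylbutyl chain, the aromatic ring still holds its advantage in this third example, with an at least 32-fold lower number from compound 1 to compound 4 (1.51 log units; beyond the scatter). Compound 1 stands at a limit of the assay rather than at a number, so the step from it gives only a minimum size: the limit of > 10000 nM in this assay, at which 1 of the 4 values shown sits.

The three rings differ at once in which groups they carry and in how many, and these two changes cannot be told apart here. As far as these compounds go, it also stays open where a phenyl ring carrying a single chlorine or an amine, or a saturated ring such as cyclohexyl, would fall on this carbonyl carbon.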